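Without the 2,5-dioxopyrrolidin-3-yl group

The source may report more compounds than this note shows. Statements on the series, on what has been measured and on what is new or still open speak of the compounds shown alone.

Measured in a functional assay on Hs 683 cells (Homo sapiens) for cytotoxicity, read by MTT assay, with a stated time of 72 h; on this read-out higher numbers stand for weaker inhibition and lower numbers for stronger inhibition:
- Compound 1 `COc1ccc2[nH]c(-c3ccc[nH]3)c(C3CC(=O)NC3=O)c2c1`: 6000 nM
- Compound 2 `O=C1CC(c2c(-c3ccc[nH]3)[nH]c3ccccc23)C(=O)N1`: 25000 nM

Compound 1 has the lower of these two numbers, which makes it the stronger inhibitor of the pair. Compound 3 `COc1ccc2[nH]c(-c3ccc[nH]3)cc2c1` has not been measured yet. It is compound 1 with hydrogen in place of 2,5-dioxopyrrolidin-3-yl on an aromatic carbon. Going by the values given here, the only measured step, a 4.2-fold higher number from compound 1 to compound 2 (0.62 log units; beyond the scatter), replaces methoxy with hydrogen. Among the compounds with values here, compound 3 keeps its methoxy, so that step does not test this change, and no measured pair removes this group. That step offers only a rough scale for a single change on the shared core. On so little evidence, a modest move toward weaker inhibition in this assay is expected, and the uncertainty is wide. The expected step is a 3.3-fold higher number from compound 1 to compound 3 (0.52 log units; beyond the scatter). Compound 3 is estimated at 20000 nM, with an expected range from 5000 nM to 80000 nM.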

Compound 3, half-maximal inhibitory concentration: 50000 nM
For compound 3 the middle estimate is 2.5-fold (0.40 log units) below the measured one; the measured number falls inside the stated range.
By their numbers in this assay, from the lowest: compound 1; then compounds 2 and 3 (each within the scatter of the next).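

Replacing the 2,5-dioxopyrrolidin-3-yl group with hydrogen on this aromatic carbon gives, in this assay, an 8.3-fold higher number from compound 1 to compound 3 (0.92 log units; beyond the scatter) and so moves toward weaker inhibition. The earlier step changed only the methoxy, whereas this one keeps the methoxy and shows that the carbon next to the ring atom bearing the 1H-pyrrol-2-yl group also matters for this read-out. No measurement available here explains why the loss of this group weakens inhibition.

The compounds shown leave open whether the whole five-membered non-aromatic ring is needed, or whether a smaller group on this carbon, such as an amine or a carboxylic acid, would serve as well. They also leave open whether the methoxy counts for as much once the 2,5-dioxopyrrolidin-3-yl group is gone.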